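The compounds below may be only part of what the source reports. "The series", "measured", "known", "first", "only" and "open" are said of these compounds alone.

In an assay on CHO cells for displacement of a labelled ligand from adenosine receptor A1 (Homo sapiens), read by scintillation counting, with a stated time of 120 min, tested at 10 uM (on this read-out higher numbers stand for more inhibition at the one concentration tested (going by the name of the read-out) and lower numbers for less inhibition), compound 3 `Nc1scc(CN2CCN(c3ccc(F)cc3F)CC2)c1C(=O)c1ccc(Cl)cc1` gives 1%. The two compounds that share its core and differ from it only in the group on the amine nitrogen in a ring give numbers of the same kind: compound 1 `Nc1scc(CN2CCN(c3cccc(C(F)(F)F)c3)CC2)c1C(=O)c1ccc(Cl)cc1` gives 0% and compound 2 `Nc1scc(CN2CCN(c3cccnc3)CC2)c1C(=O)c1ccc(Cl)cc1` gives 0%. Compound 3 carries the largest figure of the three, but a number 1 percentage points higher from compound 1 to compound 3 (within the scatter) and a number 1 percentage points higher from compound 2 to compound 3 (within the scatter) show that this sets it apart from neither, and no change at the digits printed from compound 1 to compound 2 (within the scatter) completes a picture in which all three aryl groups leave the read-out at the floor.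

Compound 4 `Nc1scc(CN2CCN(c3c(F)cc(F)cc3F)CC2)c1C(=O)c1ccc(Cl)cc1` is the next compound. Its difference from compound 3 is fluoro in place of hydrogen on an aromatic carbon. Going by the values given here, no measured step adds a single fluoro to an already fluorinated ring; the three measured steps exchange the whole aryl group and all stay within the scatter. Since compound 3 gives 1% and none of the larger exchanges moved the number, for compound 4 the expected step is no change at the digits printed from compound 3 to compound 4 (within the scatter), none beyond the scatter. Compound 4 is therefore estimated at 1%, with a range from -6% to 9%.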

Compound 4, a percentage reported as inhibition, at one concentration (the size of the read-out at that concentration, not a potency): 0%
For compound 4 the middle estimate is 1 percentage points above the measured one; the range from low to high includes it.
By their numbers in this assay, from the lowest: compounds 1, 2, 4 and 3 (each within the scatter of the next).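

In this assay, going by these compounds alone, fluoro in place of hydrogen on the aromatic carbon ortho to a large group and meta to two fluoro groups gives a number 1 percentage points lower from compound 3 to compound 4 (within the scatter) and is the first change in this set confined to one atom, so a step this small at this position does not lift the read-out from the floor any more than the exchanges of the whole aryl group did. The 2,4,6-trifluorophenyl group also stands level with the other aryl groups, with no change at the digits printed from compound 2 to compound 4 (within the scatter) against pyridin-3-yl and no change at the digits printed from compound 1 to compound 4 (within the scatter) against 3-(trifluoromethyl)phenyl, so all four compounds sit together at the floor of this read-out. Nothing available accounts for this flat result.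

With every number at the floor, the compounds shown cannot tell whether any of these aryl groups is better or worse than another at this receptor. As far as these compounds go, it stays open whether an amine or a carboxylic acid on that aryl ring, a longer alkyl chain in place of the aryl group, or a methoxy group in place of the chloro on the other ring would give a number above the floor.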